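The source may report more compounds than this note shows. Statements on the series, on what has been measured and on what is new or still open speak of the compounds shown alone.

Measured compounds:
Compound 1, `COc1cc2c(Oc3ccc(NC(=O)c4nn(-c5cccc(F)c5)c(=O)cc4C)cc3F)ccnc2cc1OCCCN1CCCCC1`: 290 nM
Compound 2, `COc1cc2c(Oc3ccc(NC(=O)c4nn(-c5cccc(F)c5)c(=O)cc4C)cc3F)ccnc2cc1OCCCN1CCC(C)CC1`: 300 nM
Compound 3, `COc1cc2c(Oc3ccc(NC(=O)c4nn(-c5ccc(Cl)cc5)c(=O)cc4C)cc3F)ccnc2cc1OCCCN1CCCCC1`: 360 nM

All three were examined in a functional assay on HT-29 cells (Homo sapiens) for inhibition, read by MTT assay, with a stated time of 72 h; on this read-out higher numbers stand for weaker inhibition and lower numbers for stronger inhibition. Compound 1 and compound 2 differ by methyl in place of hydrogen on a saturated ring carbon, and this gave a 1.0-fold higher number from compound 1 to compound 2 (0.01 log units; within the scatter). Compound 1 and compound 3 differ in their cores by 4-chlorophenyl in place of 3-fluorophenyl on an aromatic nitrogen, with a 1.2-fold higher number from compound 1 to compound 3 (0.09 log units; within the scatter). Compound 4, `COc1cc2c(Oc3ccc(NC(=O)c4nn(-c5ccc(Cl)cc5)c(=O)cc4C)cc3F)ccnc2cc1OCCCN1CCC(C)CC1`, has not yet been measured in this assay. Among the compounds with values here, it differs from compound 3 by methyl in place of hydrogen on a saturated ring carbon; this is the same change as the one from compound 1 to compound 2, placed identically. Because a 1.0-fold higher number from compound 1 to compound 2 (0.01 log units; within the scatter) stayed within the scatter, compound 4 is expected to sit close to compound 3, and the estimated step is a 1.0-fold higher number from compound 3 to compound 4 (0.01 log units; within the scatter). Compound 4 is therefore estimated at 370 nM, with a likely range from 200 nM to 700 nM in this assay.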

Compound 4, half-maximal inhibitory concentration: 180 nM
Compound 4: the middle estimate sits 2.1-fold (0.31 log units) above what was measured; the measured number lies below the stated range.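

In this assay, 4-methylpiperidin-1-yl in place of piperidin-1-yl gave a 2.0-fold lower number from compound 3 to compound 4 (0.30 log units; within the scatter), and this step can be set beside the same change on the other core: the same change on two cores in this assay, a 1.0-fold higher number (0.01 log units; within the scatter) from compound 1 to compound 2 and a 2.0-fold lower number (0.30 log units; within the scatter) from compound 3 to compound 4, 2.1-fold (0.32 log units) apart, within the scatter of two such steps. The change to 4-chlorophenyl in place of 3-fluorophenyl on an aromatic nitrogen gave a 1.7-fold lower number from compound 2 to compound 4 (0.22 log units; within the scatter), and it compares with its earlier step as follows: the same change on two cores in this assay, a 1.2-fold higher number (0.09 log units; within the scatter) from compound 1 to compound 3 and a 1.7-fold lower number (0.22 log units; within the scatter) from compound 2 to compound 4, 2.1-fold (0.32 log units) apart, within the scatter of two such steps. Each change therefore read alike on the two cores within the scatter, but this rests on a single pair of steps per change and does not show that either change would carry to further cores.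

The compounds shown leave open how a morpholin-4-yl or 4-methylpiperazin-1-yl group in place of piperidin-1-yl would read. They also leave open whether a longer chain to the ring nitrogen would alter these steps.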